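Moving the chlorine on a pyridine series against prostate cancer cells

The source may report more compounds than this note shows. Statements on the series, on what has been measured and on what is new or still open speak of the compounds shown alone.

Three measured compounds share a pyridine bearing a hydroxyphenyl group, a thiophene and a chlorophenyl group, and they were tested in a functional assay on DU-145 cells (Homo sapiens) for cytotoxicity, read by CCK-8 assay and cell counting, with a stated time of 2 days; a lower number here means a stronger inhibitor, a higher number a weaker inhibitor. Compound 1 `Oc1ccc(-c2cc(-c3ccc(Cl)cc3)nc(-c3cccs3)c2)cc1` gives 7660 nM. Compound 2 `Oc1ccc(-c2cc(-c3cccc(Cl)c3)nc(-c3cccs3)c2)cc1` gives 5740 nM. Compound 3 `Oc1cccc(-c2cc(-c3ccc(Cl)cc3)nc(-c3ccsc3)c2)c1` gives 11600 nM, and its two companions lie close by: compound 1 is nearest and compound 2 furthest.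

Among the compounds with values here, the one change that is measured is 3-chlorophenyl in place of 4-chlorophenyl on an aromatic carbon. It made a 1.3-fold lower number from compound 1 to compound 2 (0.13 log units; within the scatter). The same kind of change is now proposed on the core of compound 3, giving compound 4 `Oc1cccc(-c2cc(-c3ccsc3)nc(-c3cccc(Cl)c3)c2)c1`; here it reads (3-chlorophenyl in place of 4-chlorophenyl on an aromatic carbon). The surroundings are not identical: in compound 1 the changed position is meta to a 4-hydroxyphenyl group and meta to a thiophen-2-yl group, while in compound 3 it is meta to a 3-hydroxyphenyl group and meta to a thiophen-3-yl group. The difference between the two cores is not broken down here.

Because the earlier step was a 1.3-fold lower number from compound 1 to compound 2 (0.13 log units; within the scatter) and lay within the scatter, a similarly small step is expected from compound 3 to compound 4, estimated as a 1.3-fold lower number from compound 3 to compound 4 (0.11 log units; within the scatter). Within the data shown here, with only one prior example of this change, the expectation is loose. For compound 4 the estimated value in this assay is 9000 nM, expected to fall between 4500 nM and 18000 nM.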

Compound 4, half-maximal inhibitory concentration: 3330 nM
Beside the measured number, compound 4's estimate is 2.7-fold (0.43 log units) above it; measured number below the stated range.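

In this assay putting 3-chlorophenyl in place of 4-chlorophenyl on the second core gave a 3.5-fold lower number from compound 3 to compound 4 (0.54 log units; beyond the scatter) and so clears the usual scatter, which the same change on the first core did not do. Although the two results look different at first sight, the gap between them is no larger than two such steps can show by scatter alone: the same change on two cores in this assay, a 1.3-fold lower number (0.13 log units; within the scatter) from compound 1 to compound 2 and a 3.5-fold lower number (0.54 log units; beyond the scatter) from compound 3 to compound 4, 2.6-fold (0.42 log units) apart, within the scatter of two such steps. This means there is no firm sign that the change behaves differently on the two cores, but with only one pair of compounds for each core, it is not shown that the change behaves identically on them either, nor what it would do on a further core.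

The compounds shown leave open whether the result depends on the hydroxyphenyl group, the thiophene or both, since the two cores differ in each of these at once and neither difference is examined alone. They also leave open what would happen if the chlorine gave way to a fluorine or a methoxy group, or if the hydroxyl group gave way to an amine or a carboxylic acid.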